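Replacing Bromo with Methoxy on the Aromatic Ring

The source may hold more compounds than are shown below. What is called first, only, known or untested is meant among the compounds shown, and "the series" means these compounds.

For the measured compounds named here, in a functional assay on CCRF-CEM cells (Homo sapiens) for inhibition (a lower number here means a stronger inhibitor, a higher number a weaker inhibitor), compound 1 `O=C1CCCCC/C1=C\c1ccccc1` gives 110000 nM, while compound 2 `O=C1CCCCC/C1=C\c1ccc(Br)cc1` gives 42800 nM, the lower of the two numbers measured so far. Compound 3 `COc1ccc(/C=C2\CCCCCC2=O)cc1` has not yet been measured. It differs from compound 2 in one place: methoxy in place of bromo on an aromatic carbon. This is methoxy in place of bromo on an aromatic carbon, para to a group of 9 heavy atoms. Going by the values given here, only one measured step bears on this change: a 2.6-fold lower number from compound 1 to compound 2 (0.41 log units; beyond the scatter), a modest step beyond the scatter, with bromo in place of hydrogen on an aromatic carbon. Among the compounds with values here, no measured compound carries methoxy, so the evidence is thin. Compound 3 is expected to lose part of that modest improvement, moving to a somewhat higher number in this assay. The expected step is a 1.8-fold higher number from compound 2 to compound 3 (0.24 log units; within the scatter). For compound 3 the estimated value is 75000 nM, with an expected range from 30000 nM to 170000 nM.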

Compound 3, half-maximal inhibitory concentration: 194000 nM
For compound 3 the middle estimate is 2.6-fold (0.41 log units) below the measured one; the measured number lies above the stated range.
By their numbers in this assay, from the lowest: compound 2; then compounds 1 and 3 (each within the scatter of the next).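

In this assay the exchange of bromo for methoxy gives a 4.5-fold higher number from compound 2 to compound 3 (0.66 log units; beyond the scatter) and so shows that the lower number of compound 2 does not come with just any group placed on this aromatic carbon. With a 1.8-fold higher number from compound 1 to compound 3 (0.25 log units; within the scatter) for methoxy in place of hydrogen, methoxy cannot be told apart from hydrogen at this position, and among the three compounds only bromo stands apart. Nothing measured here accounts for the difference between bromo and methoxy.

Going by these compounds, it remains open whether the lower number belongs to bromo alone or would also appear with chloro, an amine or a carboxylic acid at this place. For the compounds shown here, it is also open whether the gap between bromo and methoxy would hold on a core other than the one these three compounds share.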